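The source may report more compounds than this note shows. Statements on the series, on what has been measured and on what is new or still open speak of the compounds shown alone.

Of the compounds shown here, three with a shared core have so far been measured in an ADME assay on cells (Hepatocyte, Homo sapiens) for metabolic stability; on this read-out higher numbers stand for a longer-lived compound and lower numbers for a shorter-lived compound. Compound 1 `O=C(C1CCN(c2ccncn2)CC1)N1N=CC[C@H]1c1ccccc1` gives 3.3 h in this assay. Compound 2 `Cc1nnc(N2CCC(C(=O)N3N=CC[C@H]3c3ccccc3)CC2)o1` gives 3.3 h, and compound 3 `Cc1nnc(N2CCC(C(=O)N3N=CC[C@H]3c3cc(F)cc(F)c3)CC2)o1` gives 3.3 h. Compound 2 thus stands level with compound 1 and compound 3: the step of no change at the digits printed from compound 1 to compound 2 (within the scatter) and the step of no change at the digits printed from compound 2 to compound 3 (within the scatter) both lie within the usual scatter of this assay, so no ordering among the three can be claimed.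

Compound 4 `O=C(C1CCN(c2cccnn2)CC1)N1N=CC[C@H]1c1ccccc1` has not yet been measured. It differs from compound 2 in one place: pyridazin-3-yl in place of 5-methyl-1,3,4-oxadiazol-2-yl on an amine nitrogen in a ring. Of the measured steps, only the first bears on this change, since it also exchanged one small aromatic group for another on the same amine nitrogen in a ring and left the half-life unchanged within the scatter. Among the measured compounds shown here, no step in the data shows this position to move the half-life. Compound 4 is therefore expected to give 3.3 h, with a range from 1.7 h to 6.6 h. The expected step of no change at the digits printed from compound 2 to compound 4 (within the scatter) is estimated to stay within the scatter.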

Compound 4, half-life: 2.32 h
The estimate for compound 4 lay 1.4-fold (0.15 log units) above the measured number; the range from low to high includes it.
By their numbers in this assay, from the lowest: compounds 4, 1, 2 and 3 (each within the scatter of the next).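

In this assay, the swap to pyridazin-3-yl on the amine nitrogen gives a 1.4-fold lower number from compound 2 to compound 4 (0.15 log units; within the scatter) and, set against the six-membered pyrimidin-4-yl, gives a 1.4-fold lower number from compound 1 to compound 4 (0.15 log units; within the scatter) as well. Among the compounds shown here, this position has now carried three different aromatic rings, five- and six-membered, and no step between them leaves the scatter, so the earlier single exchange of rings here is no longer the only evidence that such swaps leave the half-life in place. No measurement shown here explains why these steps stay so small.

As far as these compounds go, all three groups at this position are aromatic rings, so it stays open whether a longer alkyl chain or a carboxylic acid on the same nitrogen would also leave the half-life within the scatter. From the compounds shown here alone, it is also open whether pyridazin-3-yl would behave the same way with 3,5-difluorophenyl in place of phenyl.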